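Benzofuran swap on the furan compound: working notes

A few compounds are considered here, and "the series" means these few. Any claim that something is new, unique, unknown or untested is made for them only; others in the source may bear on it.

Compound 1 `COc1ncnc2c1c(-c1cc3ccccc3o1)cn2[C@@H]1O[C@H](CO)[C@@H](O)[C@H]1O`: > 20000 nM (a limit)
Compound 2 `CN(C)c1ncnc2c1c(-c1ccoc1)cn2[C@@H]1O[C@H](CO)[C@@H](O)[C@H]1O`: 12500 nM

Among the measured compounds shown here, in a functional assay on HepG2 cells (Homo sapiens) for antiproliferative activity, read by XTT assay, with a stated time of 72 h (on this read-out lower numbers stand for stronger inhibition and higher numbers for weaker inhibition), compound 2 gives the only actual number so far, 12500 nM. Compound 3 `CN(C)c1ncnc2c1c(-c1cc3ccccc3o1)cn2[C@@H]1O[C@H](CO)[C@@H](O)[C@H]1O` carries 1-benzofuran-2-yl in place of furan-3-yl on an aromatic carbon. For the measured compounds named here, no measured step isolates this change. Compound 1, which also carries 1-benzofuran-2-yl, reports only a limit, > 20000 nM. On that guide, the expected step in this assay is small and towards weaker inhibition, possibly none beyond the scatter, with an estimated 1.4-fold higher number from compound 2 to compound 3 (0.16 log units; within the scatter). For compound 3 the expected value is 18000 nM, within an estimated range of 7000 nM to 40000 nM.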

Compound 3, half-maximal inhibitory concentration: > 20000 nM
Compound 3 gave a limit, no number; the forecaster's own chance of this, stated with the estimate: 55%; at least 1.1-fold (0.04 log units) between middle value and limit.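

In this assay, 1-benzofuran-2-yl in place of furan-3-yl on this aromatic carbon gives the first step readable at this position: an at least 1.6-fold higher number from compound 2 to compound 3 (0.20 log units; that floor lies within the scatter). This is only a floor, so the change is not shown to go beyond the scatter. Its true size stays unknown, and the step between methoxy and dimethylamino cannot be read, because compound 1 and compound 3 both stand at a limit: the limit of > 20000 nM in this assay, at which 2 of the 3 values shown sit.

Open, on these data alone, is what a phenyl group or an aminomethyl group on this aromatic carbon would give in this assay. Also open, as far as these compounds go, is whether a methoxy or dimethylamino group matters at all once 1-benzofuran-2-yl is present.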